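The source may report more compounds than this note shows. Statements on the series, on what has been measured and on what is new or still open speak of the compounds shown alone.

Of the compounds shown here, two of a shared core have been tested in a functional assay on MCF7 cells (Homo sapiens) for cytotoxicity, read by sulforhodamine B assay, with a stated time of 48 h, tested at 100 nM; on this read-out lower numbers stand for a stronger effect and higher numbers for a weaker effect at the one concentration tested. Compound 1, `Cc1cc(O)cc(-c2nn(CC#N)cc2-c2ccnc(-c3ccc(Oc4ccccc4)cc3)c2)c1`, gives 95% in this assay. Compound 2, `COc1cc(C)cc(-c2nn(CC#N)cc2-c2ccnc(-c3ccc(N(C)C)cc3)c2)c1`, gives 24% in this assay, the lower of the two numbers, and it lies a long way below compound 1, well beyond the scatter. Compound 3, `Cc1cc(O)cc(-c2nn(CC#N)cc2-c2ccnc(-c3ccc(N(C)C)cc3)c2)c1`, has not yet been measured. It differs from compound 2 in one place: hydrogen in place of methyl on an oxygen on an aromatic ring. For the measured compounds named here, no pair of measured compounds shows this change on its own, so its size cannot be read from the numbers at hand. A change this small at one oxygen is expected to move the read-out only a little, towards a weaker effect if at all; the step from compound 2 to compound 3 is estimated at a number 14 percentage points higher from compound 2 to compound 3 (beyond the scatter), close to the edge of the scatter. Compound 3 is therefore expected to give about 38% in this assay, within a range from 12% to 70%.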

Compound 3, a percentage reported as activity, at one concentration (the size of the read-out at that concentration, not a potency): 50%
Estimate against measurement, compound 3: 12 percentage points below; the range from low to high includes it.
By their numbers in this assay, from the lowest: compound 2; then compound 3; then compound 1.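

In this assay, the change from methoxy to hydroxy on the aromatic ring comes to a number 26 percentage points higher from compound 2 to compound 3 (beyond the scatter), so with dimethylamino held constant, the methyl on this oxygen matters to the read-out, and the methoxy form has the stronger effect. Compound 3 also connects the other two compounds: with hydroxy held constant, dimethylamino in place of phenoxy gives a number 45 percentage points lower from compound 1 to compound 3 (beyond the scatter), a large step, whereas the change at the oxygen is a modest one. The data at hand offer no explanation for either step.

Going by these compounds, whether the change from methoxy to hydroxy would have the same size with phenoxy in place of dimethylamino remains open. Also open, on these data alone, is how a longer chain on the oxygen, or a primary amine or carboxylic acid in place of dimethylamino, would read in this assay.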